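The compounds below may be only part of what the source reports. "The series", "measured", "known", "first", "only" and "open" are said of these compounds alone.

Within the data shown here, in an ADME assay on S9 fraction from liver (Rattus norvegicus) for metabolic stability, with a stated time of 1 h (on this read-out higher numbers stand for a more stable compound and lower numbers for a less stable compound), compound 1 (`N#Cc1cnc(NCc2cnccc2C(F)(F)F)cc1N[C@H]1CC[C@@H](O)CC1`) gives 6% and compound 2 (`N#Cc1cnc(NCc2cnccc2C(F)(F)F)cc1NC[C@H]1CC[C@@H](O)CC1`) gives 18% as the higher of the two numbers so far. Still unmeasured is compound 3 (`N#Cc1cnc(NCc2cnccc2C(F)(F)F)cc1NC1CCOCC1`), which carries oxan-4-yl in place of (4-hydroxycyclohexyl)methyl on a nitrogen on an aromatic ring. Among the measured compounds shown here, only one measured step bears on this change, and only in part. For the measured compounds named here, the modest step of a number 12 percentage points higher from compound 1 to compound 2 (beyond the scatter) brought in the (4-hydroxycyclohexyl)methyl group that now leaves, but it shows nothing about oxan-4-yl, which has no measured precedent in this assay here. Going by these compounds, a step larger than that one is therefore not expected, and the direction stays open. The expected result is a number 4 percentage points higher from compound 2 to compound 3 (within the scatter) (no shift beyond the scatter is expected, with more room upward than downward). For compound 3 the estimate is 22% (expected range 7% to 50%).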

Compound 3, percent of the compound remaining: 17%
For compound 3 the middle estimate is 5 percentage points above the measured one; the measured number falls inside the stated range.
By their numbers in this assay, from the lowest: compound 1; then compounds 3 and 2 (each within the scatter of the next).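

In this assay, oxan-4-yl in place of (4-hydroxycyclohexyl)methyl on this nitrogen gives a number 1 percentage points lower from compound 2 to compound 3 (within the scatter), so a group with 6 heavy atoms and 0 hydrogen-bond donors sits level with one of 8 heavy atoms and 1 hydrogen-bond donor. Oxan-4-yl in place of 4-hydroxycyclohexyl gives a number 11 percentage points higher from compound 1 to compound 3 (beyond the scatter), so the rise above compound 1 does not require the (4-hydroxycyclohexyl)methyl group. Nothing available accounts for either step.

The compounds shown leave open whether the oxygen in these groups matters at this nitrogen, which a plain cyclohexyl or a piperidin-4-yl group would test. They also leave open whether another change at this nitrogen could raise the number further, or whether the rest of the shared core sets the ceiling.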